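This account rests on a few compounds, and the source may have more. Where it says the series, first, only, none or still open, it means among the compounds named here.

Working notes, series of the shared core. Compound 1 `CC(C)NC(=O)N1CCC(CN(C2Cc3cc(C#N)ccc3N(Cc3cncn3C)C2)S(=O)(=O)c2ccccn2)CC1` gives 0.6 10^-6 cm/s in an ADME assay on Caco-2 cells (Homo sapiens) for permeability, in the apical to basolateral direction; on this read-out lower numbers stand for lower permeability and higher numbers for higher permeability. Compound 2 `CCOC(=O)N1CCC(CN(C2Cc3cc(C#N)ccc3N(Cc3cncn3C)C2)S(=O)(=O)c2ccccn2)CC1` gives 2.6 10^-6 cm/s in the same assay and stands highest of the two numbers measured, its nearest neighbour being compound 1 with a 4.3-fold higher number from compound 1 to compound 2 (0.64 log units; beyond the scatter). The next compound, compound 3 `Cn1cncc1CN1CC(N(CC2CCN(S(=O)(=O)c3ccccc3)CC2)S(=O)(=O)c2ccccn2)Cc2cc(C#N)ccc21`, differs from compound 2 in one place: phenylsulfonyl in place of ethoxycarbonyl on an amine nitrogen in a ring. Among the measured compounds shown here, only the step from compound 1 to compound 2 touches this same amine nitrogen in a ring, and it was modest. For the measured compounds named here, the new change is larger in what enters, so a shift beyond the scatter in either direction cannot be ruled out; no further measured step in this assay speaks to it. For compound 3 the expectation is a value near that of compound 2, with a 1.2-fold higher number from compound 2 to compound 3 (0.06 log units; within the scatter), giving an estimate of 3 10^-6 cm/s in this assay, from 1 10^-6 cm/s to 9 10^-6 cm/s.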

Compound 3, apparent permeability: 0.1 10^-6 cm/s
For compound 3 the middle estimate is 30-fold (1.48 log units) above the measured one; measured number below the stated range.
By their numbers in this assay, from the lowest: compound 3; then compound 1; then compound 2.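

On the amine nitrogen in a ring, the choice of group matters more in this assay than the earlier pair indicated: phenylsulfonyl gives a 26-fold lower number from compound 2 to compound 3 (1.41 log units; beyond the scatter), a large step, and also a 6.0-fold lower number from compound 1 to compound 3 (0.78 log units; beyond the scatter), a modest one. Phenylsulfonyl therefore stands lowest of the three groups at this position, with its steps to both ethoxycarbonyl and isopropylcarbamoyl beyond the scatter. No measured evidence here accounts for this drop. The compounds shown leave open whether the sulfonyl link or the phenyl ring carries the step. A methylsulfonyl or benzoyl group on the same nitrogen would separate the two.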